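This account rests on a few compounds, and the source may have more. Where it says the series, first, only, none or still open, it means among the compounds named here.

Within the data shown here, compound 3 `COc1cc2ncnc(Nc3ccc(F)c(Cl)c3)c2cc1NC(=O)N/N=C/c1ccc(C#N)cc1` gives 34100 nM in a functional assay on HepG2 cells (Homo sapiens) for cytotoxicity, read by MTT assay, with a stated time of 72 h (a lower number here means a stronger inhibitor, a higher number a weaker inhibitor), the highest of the three numbers measured so far. Its nearest neighbour is compound 1 `N#Cc1ccc(/C=N/NC(=O)Nc2cc3c(Nc4ccc(F)c(Cl)c4)ncnc3cc2O[C@H]2CCOC2)cc1`, which gives 26400 nM; the change a 1.3-fold higher number from compound 1 to compound 3 (0.11 log units; within the scatter) lies within the scatter. Compound 2 `CCN(CC)c1ccc(/C=N/NC(=O)Nc2cc3c(Nc4ccc(F)c(Cl)c4)ncnc3cc2O[C@H]2CCOC2)c(O)c1` gives 15700 nM, and the difference between compound 2 and compound 3 is beyond the scatter.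

Compound 4 `COc1cc2ncnc(Nc3ccc(F)c(Cl)c3)c2cc1NC(=O)N/N=C/c1ccc(O)cc1O` differs from compound 3 in one place: 2,4-dihydroxyphenyl in place of 4-cyanophenyl on a carbon with a double bond to nitrogen. Among the measured compounds shown here, the only measured step that touches this position is a 1.7-fold lower number from compound 1 to compound 2 (0.23 log units; within the scatter), where a 4-(diethylamino)-2-hydroxyphenyl replaced the same 4-cyanophenyl, and that step stayed within the scatter. For the measured compounds named here, no measured pair shows a 2,4-dihydroxyphenyl itself, so the step of a 1.4-fold lower number from compound 3 to compound 4 (0.13 log units; within the scatter) is expected to be small, with at most a slight move toward a lower number. Compound 4 is therefore estimated at 25000 nM, with a range from 10000 nM to 60000 nM.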

Compound 4, half-maximal inhibitory concentration: 32100 nM
The estimate for compound 4 lay 1.3-fold (0.11 log units) below the measured number, within the range that was stated.
By their numbers in this assay, from the lowest: compounds 2, 1, 4 and 3 (each within the scatter of the next, the first and the last beyond it).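

In this assay, putting 2,4-dihydroxyphenyl in place of 4-cyanophenyl on the carbon with a double bond to nitrogen gave a 1.1-fold lower number from compound 3 to compound 4 (0.03 log units; within the scatter), so the loss of the nitrile and the arrival of two hydroxyl groups left no readable difference in this assay. Until now this position had been seen only through a 1.7-fold lower number from compound 1 to compound 2 (0.23 log units; within the scatter), with oxolan-3-yl on the oxygen on the aromatic ring; the new step shows a second replacement group, with methyl on that oxygen, that also stays within the scatter. Nothing measured here bears on this result.

The compounds shown leave open whether an amine or a carboxylic acid on this phenyl ring would give a step beyond the scatter. They also leave open how 2,4-dihydroxyphenyl reads with oxolan-3-yl on that oxygen.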